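From a chloropropyl amide to a pentyl urea

A few compounds are considered here, and "the series" means these few. Any claim that something is new, unique, unknown or untested is made for them only; others in the source may bear on it.

Of the compounds shown here, three that share one core have been tested in a functional assay on MCF7 cells (Homo sapiens) for antiproliferative activity, read by sulforhodamine B assay, with a stated time of 48 h; a higher number here means a weaker inhibitor, a lower number a stronger inhibitor. Compound 1 `CCCC(=O)Nc1ccc(S(=O)(=O)Oc2ccccc2C(C)C)cc1` gives 6600 nM. Compound 2 `CC(C)c1ccccc1OS(=O)(=O)c1ccc(NC(=O)CCCl)cc1` gives 9000 nM, and compound 3 `CC(C)c1ccccc1OS(=O)(=O)c1ccc(NC(=O)CCCCl)cc1` gives 5200 nM. Compound 3 has the lowest of the three numbers, but every step among them stays within the scatter: a 1.4-fold higher number from compound 1 to compound 2 (0.13 log units; within the scatter), a 1.3-fold lower number from compound 1 to compound 3 (0.10 log units; within the scatter) and a 1.7-fold lower number from compound 2 to compound 3 (0.24 log units; within the scatter). On these numbers the three compounds cannot be told apart.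

Compound 4 `CCCCCNC(=O)Nc1ccc(S(=O)(=O)Oc2ccccc2C(C)C)cc1` is the next compound. It differs from compound 3 in one place: pentylamino in place of 3-chloropropyl on a carbonyl carbon. Going by the values given here, none of the measured steps touches the carbonyl carbon itself; each of them only altered the chain that now leaves, and none of them moved the number beyond the scatter. Among the compounds with values here, no measured step therefore bears directly on this change, and the expectation rests only on how little the earlier chain changes have mattered. For compound 4 the expected step is a 1.0-fold lower number from compound 3 to compound 4 (0.02 log units; within the scatter), that is, no change beyond the scatter, with a wide band around it. Compound 4 is therefore estimated at 5000 nM, expected to lie between 1500 nM and 16000 nM.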

Compound 4, half-maximal inhibitory concentration: 4000 nM
For compound 4 the middle estimate is 1.3-fold (0.10 log units) above the measured one, within the range that was stated.
By their numbers in this assay, from the lowest: compounds 4, 3, 1 and 2 (each within the scatter of the next, the first and the last beyond it).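

Replacing the chain on the carbonyl carbon with pentylamino, which turns the amide into a urea, leaves the result in this assay within the scatter of its closest relatives, with a 1.3-fold lower number from compound 3 to compound 4 (0.11 log units; within the scatter) and a 1.7-fold lower number from compound 1 to compound 4 (0.22 log units; within the scatter) as the two steps. So this carbonyl carbon can carry a nitrogen-linked chain without any measurable loss, a wider change than the earlier edits to the chain alone. Only against the 2-chloroethyl amide does the change pass the scatter, with a 2.3-fold lower number from compound 2 to compound 4 (0.35 log units; beyond the scatter) as a modest step, the first in this set to do so, but no measured property accounts for it.

The compounds shown leave open how much depends on the pentyl chain and how much on the urea itself, a question that ureas carrying a propyl chain, a longer octyl chain or a cyclohexyl ring could help to separate. Also open, from the compounds shown here alone, is whether the hydrogen on the pentylamino nitrogen matters, which a urea with a methyl group in its place would test.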